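Fluorine on the Aniline Ring Across Two Different Cores

A few compounds are considered here, and "the series" means these few. Any claim that something is new, unique, unknown or untested is made for them only; others in the source may bear on it.

Measured in a functional assay on RAW264.7 cells (Mus musculus) for inhibition; on this read-out lower numbers stand for stronger inhibition and higher numbers for weaker inhibition:
compound 1, `CCOC(=O)C1=CCCCC1S(=O)(=O)Nc1ccc(F)cc1`, gives 110 nM;
compound 2, `CCOC(=O)C1=CCCCC1S(=O)(=O)Nc1ccc(F)cc1F`, gives 16 nM;
compound 3, `CCOC(=O)C1=C(S(=O)(=O)Nc2ccccc2)CCCC1`, gives > 8200 nM, which is only a limit of the assay (the limit of > 8200 nM in this assay, at which 1 of the 3 values shown sits).

Compound 2 differs from compound 1 by fluoro in place of hydrogen on an aromatic carbon, and this gave a 6.9-fold lower number from compound 1 to compound 2 (0.84 log units; beyond the scatter). Compound 4, `CCOC(=O)C1=C(S(=O)(=O)Nc2ccc(F)cc2)CCCC1`, differs from compound 3 by fluoro in place of hydrogen on an aromatic carbon. This is the same kind of change, not the same: in compound 2 the fluoro sits ortho to a large group and meta to a fluoro group, in compound 4 para to a large group. How the core of compound 3 differs from the core of compound 1 is not broken down here. From the compounds shown here alone, since compound 3 sits at the limit (the limit of > 8200 nM in this assay, at which 1 of the 3 values shown sits), its true value is unknown, and the core itself appears to carry the loss. The step from compound 3 to compound 4 is expected to be an at least 1.3-fold lower number from compound 3 to compound 4 (0.13 log units; that floor lies within the scatter), smaller than the earlier one, resting on the different place. The estimate for compound 4 is 6000 nM, between 1500 nM and 30000 nM, with a real chance that this assay again reports only a limit.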

Compound 4, half-maximal inhibitory concentration: 1400 nM
Compound 4: the middle estimate sits 4.3-fold (0.63 log units) above what was measured, outside the stated range (below it).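

In this assay the change from phenyl to 4-fluorophenyl gives an at least 5.8-fold lower number from compound 3 to compound 4 (0.76 log units; beyond the scatter) and so the gain from adding a fluoro, first seen on the core of compound 1, also appears on a second core. This is the same kind of change rather than an identical one, since the fluoro does not stand in the same place in compound 2 and compound 4. Whether the two steps are equal in size stays unsettled: the same change on two cores in this assay, a 6.9-fold lower number (0.84 log units; beyond the scatter) from compound 1 to compound 2 and an at least 5.8-fold lower number (0.76 log units; beyond the scatter) from compound 3 to compound 4; the limit leaves it open whether they differ

Still open, from the compounds shown here alone, is whether a second fluoro would add a further gain on the core of compound 4, and whether a chloro group would serve as well as fluoro. Also open, going by these compounds, is how a carboxylic acid in place of the ethyl ester would fare on either core.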